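The compounds below may be only part of what the source reports. "The series", "measured", "known", "first", "only" and "open" are said of these compounds alone.

Two compounds of the series have numbers in a functional assay on HT-1080 cells (Homo sapiens) for cytotoxicity, read by MTT assay, with a stated time of 72 h; on this read-out lower numbers stand for stronger inhibition and higher numbers for weaker inhibition. Compound 1 `COc1cc(Nc2nc(C(=N)Nc3ccc(N4CCN(C)CC4)cc3)cc3c(-c4ccccc4)n[nH]c23)cc(OC)c1OC` gives 3400 nM. Compound 2 `N=C(Nc1ccccc1)c1cc2c(-c3ccccc3)n[nH]c2c(NC2CCCCC2)n1` gives 850 nM, the lowest of the two numbers, with compound 1 standing clearly higher, beyond the scatter. Compound 3 `CN1CCN(c2ccc(NC(=N)c3cc4c(-c5ccccc5)n[nH]c4c(NC4CCCCC4)n3)cc2)CC1` is not yet measured and differs from compound 2 in one place: 4-methylpiperazin-1-yl in place of hydrogen on an aromatic carbon. Among the measured compounds shown here, no measured pair differs by this change alone, so its size is unknown from the series; a step within the scatter, in either direction, is expected. For compound 3 a value of about 600 nM is estimated, within 200 nM to 2000 nM, which is the expected step of a 1.4-fold lower number from compound 2 to compound 3 (0.15 log units; within the scatter).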

Compound 3, half-maximal inhibitory concentration: 650 nM
For compound 3 the middle estimate is 1.1-fold (0.03 log units) below the measured one, and the stated range covers the measured number.
By their numbers in this assay, from the lowest: compounds 3 and 2 (each within the scatter of the next); then compound 1.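

In this assay, 4-methylpiperazin-1-yl in place of hydrogen on the aromatic carbon para to a large group gives a 1.3-fold lower number from compound 2 to compound 3 (0.12 log units; within the scatter), so at this position the added ring brings no change that can be told from the scatter. Among the compounds shown here, with 4-methylpiperazin-1-yl held constant, cyclohexyl in place of 3,4,5-trimethoxyphenyl on the nitrogen gives a 5.2-fold lower number from compound 1 to compound 3 (0.72 log units; beyond the scatter), the first single-place reading of that substituent. Nothing at hand accounts for the size of either step.

Open, from the compounds shown here alone, is how a morpholine or a carboxylic acid would read at the same position, and whether the cyclohexyl step holds with hydrogen in place of 4-methylpiperazin-1-yl.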